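The compounds below may be only part of what the source reports. "The series", "measured", "known", "first", "only" and "open" are said of these compounds alone.

Compounds measured in an assay on isolated protein for inhibition of DNA topoisomerase 1 (Homo sapiens), with a stated time of 30 min, tested at 100 uM; on this read-out higher numbers stand for a stronger effect at the one concentration tested and lower numbers for a weaker effect:

Compound 1 `Oc1ccccc1-c1cc(-c2cccs2)cc(-c2ccccc2O)n1` gives 77.2%.
Compound 2 `Oc1ccc(-c2cc(-c3cccs3)cc(-c3ccccc3O)n2)cc1` gives 72.2%.
Compound 3 `Oc1ccccc1-c1cc(-c2ccsc2)cc(-c2ccccc2O)n1` gives 0%.

Compound 3 stands lowest of the three numbers. Its nearest neighbour is compound 2, and the step from compound 1 to compound 3, which swaps thiophen-2-yl for thiophen-3-yl, was a number 77.2 percentage points lower from compound 1 to compound 3 (beyond the scatter), a loss well beyond the scatter of this assay. Compound 3 is therefore the starting point of a series in which the thiophen-3-yl group is kept.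

Compound 4 `Oc1ccc(-c2cc(-c3ccsc3)cc(-c3ccccc3O)n2)cc1` differs from compound 3 in one place only: 4-hydroxyphenyl in place of 2-hydroxyphenyl on an aromatic carbon

The same swap of a 2-hydroxyphenyl for a 4-hydroxyphenyl has already been measured once, on the thiophen-2-yl pair, where the step was a number 5 percentage points lower from compound 1 to compound 2 (within the scatter). That step lies within the scatter, so the swap did not visibly move the read-out there. Compound 3 sits at the bottom of the scale, which leaves little room for a further fall. On this basis the step from compound 3 to compound 4 is expected to be a number 3 percentage points higher from compound 3 to compound 4 (within the scatter), that is, no change beyond the scatter. Compound 4 is therefore estimated to give 3% in this assay, in the range 0% to 15%.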

Compound 4, a percentage reported as inhibition, at one concentration (the size of the read-out at that concentration, not a potency): 13.8%
The estimate for compound 4 lay 10.8 percentage points below the measured number; low and high end bracket the measured number.
By their numbers in this assay, from the lowest: compound 3; then compound 4; then compounds 2 and 1 (each within the scatter of the next).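

With the thiophen-3-yl group on the core, the swap of 2-hydroxyphenyl for 4-hydroxyphenyl, at the place next to the ring nitrogen, now moves the result in this assay: the step is a number 13.8 percentage points higher from compound 3 to compound 4 (beyond the scatter). The same swap therefore does not act alike on every core, and what it does here depends on which thiophene is present, something the thiophen-2-yl pair alone could not reveal: the same change on two cores in this assay, a number 5 percentage points lower (within the scatter) from compound 1 to compound 2 and a number 13.8 percentage points higher (beyond the scatter) from compound 3 to compound 4, 18.8 percentage points apart, beyond the scatter of two such steps The change from thiophen-2-yl to thiophen-3-yl now also has a second reading, a number 58.4 percentage points lower from compound 2 to compound 4 (beyond the scatter), so the large loss is not confined to the core of compound 1, although its size differs with the hydroxyphenyl group present: the same change on two cores in this assay, a number 77.2 percentage points lower (beyond the scatter) from compound 1 to compound 3 and a number 58.4 percentage points lower (beyond the scatter) from compound 2 to compound 4, 18.8 percentage points apart, beyond the scatter of two such steps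

From the compounds shown here alone, it remains open whether a 3-hydroxyphenyl, 4-methoxyphenyl or 4-aminophenyl group at this place would give a number closer to that of compound 3 or to that of compound 4. With one concentration for each compound, these percentages also leave open how the compounds compare in potency, which would take a full concentration series for each.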